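This account rests on a few compounds, and the source may have more. Where it says the series, first, only, none or still open, it means among the compounds named here.

Compound 2 `CC(=O)Nc1n[nH]c(=O)c2ccccc12` is read in an assay for inhibition of casein kinase I isoform alpha (Sus scrofa), read by scintillation counting and 33P incorporation, with a stated time of 30 min, in the presence of a further agent that is not named here (a higher number here means a weaker inhibitor, a lower number a stronger inhibitor), only as a limit, giving > 10000 nM. Compound 1 `CCCCCC(=O)Nc1n[nH]c(=O)c2ccccc12` likewise returns a limit in this assay, namely > 10000 nM. The step that the two limits leave unreadable from compound 1 to compound 2 therefore cannot be sized, since the limit of > 10000 nM in this assay, at which 2 of the 2 values shown sit, shows both values resting at the same limit. Compound 3 `CC(C)C(=O)Nc1n[nH]c(=O)c2ccccc12` differs from compound 2 by isopropyl in place of methyl on a carbonyl carbon. Within the data shown here, no measured step gives a readable size for this kind of change, so compound 3 is expected to stay at the limit, with a step that the limit leaves unreadable from compound 2 to compound 3 estimated as no readable shift. The expected value for compound 3 is 20000 nM, ranging from 5000 nM to 100000 nM.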

Compound 3, half-maximal inhibitory concentration: > 10000 nM
Compound 3 was reported as a limit; the forecaster's own chance of this, stated with the estimate: 85%; the middle value is on the limit's open side.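

No step can be read among compound 1, compound 2 and compound 3, since all three rest at one limit: the limit of > 10000 nM in this assay, at which 3 of the 3 values shown sit.

The compounds shown leave open whether any group on the carbonyl carbon would give a measurable value in this assay.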